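A few compounds are considered here, and "the series" means these few. Any claim that something is new, unique, unknown or untested is made for them only; others in the source may bear on it.

Compound 1 `CC(C(=O)N1CCCCC1)N1CCN(S(=O)(=O)c2ccc(C(C)(C)C)cc2)CC1` — in an ADME assay on HepG2 cells (Homo sapiens) for inhibition, with a stated time of 48 h (on this read-out lower numbers stand for an effect already at smaller amounts and higher numbers for an effect only at larger amounts of compound), compound 1 gives > 40000 nM, which is a limit of the assay and not a number.
Compound 2 `CC(C(=O)N1CCC(F)(F)CC1)N1CCN(S(=O)(=O)c2ccc(C(C)(C)C)cc2)CC1` — in this assay compound 2 gives > 40000 nM, again a limit of the assay rather than a number.

Going by the values given here, compound 2 therefore stands where the numbers run out: its own reading is a limit, and the only other value shown sits at the same limit (the limit of > 40000 nM in this assay, at which 2 of the 2 values shown sit). Among the compounds with values here, the single measured step, a step that the two limits leave unreadable from compound 1 to compound 2, runs between two such limits, so its size cannot be read in either direction.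

Compound 3 `CC(C(=O)N1CCOCC1)N1CCN(S(=O)(=O)c2ccc(C(C)(C)C)cc2)CC1` differs from compound 2 by morpholin-4-yl in place of 4,4-difluoropiperidin-1-yl on a carbonyl carbon. Within the data shown here, no measured step bears on this change other than the unreadable one, and both values shown sit at the limit. In this assay no movement beyond the scatter can therefore be expected in either direction, and the most probable outcome for compound 3 is a further limit. The expected step is a step that the limit leaves unreadable from compound 2 to compound 3. Compound 3 is expected to give 60000 nM, within a range from 20000 nM to 200000 nM.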

Compound 3, half-maximal effective concentration: > 40000 nM
Compound 3 was reported as a limit; the forecaster's own chance of this, stated with the estimate: 85%; the middle value does not contradict the limit.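

No new step can be read among compound 1, compound 2 and compound 3, because each of their readings in this assay is a limit of the assay and not a number: the limit of > 40000 nM in this assay, at which 3 of the 3 values shown sit.

The compounds shown leave open whether piperidin-1-yl, 4,4-difluoropiperidin-1-yl and morpholin-4-yl on the carbonyl carbon differ at all in this assay.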